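The source may report more compounds than this note shows. Statements on the series, on what has been measured and on what is new or still open speak of the compounds shown alone.

Compound 1 `CN(C)C/C=C/C(=O)Nc1cc2c(N3CCc4ccccc43)ncnc2cc1O[C@@H]1CCOC1` and compound 2 `CCN(CC)C/C=C/C(=O)Nc1cc2c(N3CCc4ccccc43)ncnc2cc1O[C@@H]1CCOC1` share one core and differ in a single place: diethylamino in place of dimethylamino on a saturated chain carbon bound to a double-bonded chain carbon. In a functional assay on PC-3 cells (Homo sapiens) for antiproliferative activity, read by MTT assay, with a stated time of 72 h (on this read-out higher numbers stand for weaker inhibition and lower numbers for stronger inhibition), compound 1 gives 1230 nM and compound 2 gives 5780 nM, so the change produced a 4.7-fold higher number from compound 1 to compound 2 (0.67 log units; beyond the scatter). Compound 3 `COc1cc2ncnc(N3CCCc4ccccc43)c2cc1NC(=O)/C=C/CN(C)C` carries the dimethylamino group on another core; the difference between the two cores is not broken down here. In this assay compound 3 gives 1750 nM, which lies within the scatter of compound 1. Compound 4 `CCN(CC)C/C=C/C(=O)Nc1cc2c(N3CCCc4ccccc43)ncnc2cc1OC` is the unmeasured partner of compound 3, with diethylamino in place of dimethylamino on a saturated chain carbon bound to a double-bonded chain carbon, the same change as between compound 1 and compound 2 at the same place. Because a 4.7-fold higher number from compound 1 to compound 2 (0.67 log units; beyond the scatter) was modest and beyond the scatter, the step expected for compound 4 is a 4.3-fold higher number from compound 3 to compound 4 (0.63 log units; beyond the scatter). Compound 4 is therefore estimated at 7500 nM, expected between 3000 nM and 18000 nM.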

Compound 4, half-maximal inhibitory concentration: 6890 nM
For compound 4 the middle estimate is 1.1-fold (0.04 log units) above the measured one; measured number inside the range.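

In this assay, the change to diethylamino gave a 3.9-fold higher number from compound 3 to compound 4 (0.60 log units; beyond the scatter). Set beside the earlier step, its size held on both cores: the same change on two cores in this assay, a 4.7-fold higher number (0.67 log units; beyond the scatter) from compound 1 to compound 2 and a 3.9-fold higher number (0.60 log units; beyond the scatter) from compound 3 to compound 4, 1.2-fold (0.08 log units) apart, within the scatter of two such steps. This supports carrying the change between these two cores only; two pairs in one cell assay show nothing about other cores or other assays, and they do not explain why the number rises.

Still open, from the compounds shown here alone, is where cyclic amines such as pyrrolidine, piperidine or morpholine would fall on either core when placed on the same saturated chain carbon. Also open, going by these compounds, is whether a longer chain on the amine nitrogen, such as dipropylamino, would extend the step seen with diethylamino.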